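Carbonyl substituent change from compound 3 to compound 4

The source may hold more compounds than are shown below. What is called first, only, known or untested is meant among the compounds shown, and "the series" means these compounds.

Values so far in a functional assay on MCF7 cells (Homo sapiens) for cytotoxicity, read by MTT assay, with a stated time of 48 h; a lower number here means a stronger inhibitor, a higher number a weaker inhibitor
- compound 1 `CCN(CC)C(=S)SC(CC(=O)c1ccccc1)c1ccccc1` (17000 nM)
- compound 2 `CCN(CC)C(=S)SC(CC(=O)c1ccccc1)c1cccc([N+](=O)[O-])c1` (9000 nM)
- compound 3 `CCN(CC)C(=S)SC(CC(C)=O)c1ccccc1` (23000 nM)

Compound 3 (23000 nM) lies within the scatter of compound 1 and has a higher number than compound 2, beyond the scatter. Compound 4 `CCN(CC)C(=S)SC(CC(=O)c1ccc(OC)cc1)c1ccccc1` is not yet measured. Its difference from compound 3 is 4-methoxyphenyl in place of methyl on a carbonyl carbon. Among the measured compounds shown here, two measured steps bear on this: methyl in place of phenyl on a carbonyl carbon gave a 1.4-fold higher number from compound 1 to compound 3 (0.13 log units; within the scatter), and nitro in place of hydrogen on an aromatic carbon gave a 1.9-fold lower number from compound 1 to compound 2 (0.28 log units; within the scatter). For the measured compounds named here, no measured compound carries a 4-methoxyphenyl group. No step beyond the scatter is therefore expected in this assay. The expected step is a 1.5-fold lower number from compound 3 to compound 4 (0.19 log units; within the scatter). Compound 4 is estimated at 15000 nM, with an expected range from 7000 nM to 30000 nM.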

Compound 4, half-maximal inhibitory concentration: 4500 nM
Beside the measured number, compound 4's estimate is 3.3-fold (0.52 log units) above it, and the stated range ends above it.
By their numbers in this assay, from the lowest: compounds 4, 2, 1 and 3 (each within the scatter of the next, the first and the last beyond it).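

In this assay, a change on the carbonyl carbon now gives a step beyond the scatter, a 5.1-fold lower number from compound 3 to compound 4 (0.71 log units; beyond the scatter), although the earlier exchange of phenyl and methyl there stayed within it. Adding the methoxy group to the phenyl ring also gives a step beyond the scatter, a 3.8-fold lower number from compound 1 to compound 4 (0.58 log units; beyond the scatter), so the methoxy group matters here and the phenyl ring alone does not account for the result. No measured evidence accounts for these steps. From the compounds shown here alone, whether a hydroxyl, an ethoxy or a dimethylamino group at this ring position gives a similar step remains open, as does the effect of methoxy combined with the nitro group of compound 2.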